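Aryl methyl to methoxy on the pyrimidinylthio hydrazide series

This account rests on a few compounds, and the source may have more. Where it says the series, first, only, none or still open, it means among the compounds named here.

Measured so far:
compound 1 `COc1ccc(-c2cs/c(=N/NC(=O)CSc3nnc(C)s3)n2-c2ccccc2)cc1` — a functional assay on C6 cells (Rattus norvegicus) for cytotoxicity, read by MTT assay, with a stated time of 24 h, tested at 50 ug/mL; on this read-out higher numbers stand for a weaker effect at the one concentration tested and lower numbers for a stronger effect: 31.5%
compound 2 `O=C(CSc1ncccn1)N/N=c1/scc(-c2ccc(Cl)cc2)n1-c1ccccc1` — this assay : 61.8%
compound 3 `Cc1ccc(-c2cs/c(=N/NC(=O)CSc3ncccn3)n2-c2ccccc2)cc1` — this assay : 64.4%

Compound 3 holds the highest of the three numbers. Among the compounds with values here, compound 2 is nearest to it, and the only single-place step measured, a number 2.6 percentage points higher from compound 2 to compound 3 (within the scatter), lies within the scatter. Compound 1 is furthest from compound 3, but compound 1 differs from compound 3 in two places, so its lower number cannot be tied to the aryl group alone.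

Compound 4 `COc1ccc(-c2cs/c(=N/NC(=O)CSc3ncccn3)n2-c2ccccc2)cc1` differs from compound 3 by methoxy in place of methyl on an aromatic carbon. Within the data shown here, no measured step covers this exact change. Among the measured compounds shown here, the one step at the same place, a number 2.6 percentage points higher from compound 2 to compound 3 (within the scatter), was within the scatter, which argues for a small movement here as well. Compound 1, which also carries methoxy, gives 31.5%, showing a much lower number is possible for a methoxy compound, though the second difference in compound 1 leaves that unresolved. A step of a number 12.4 percentage points lower from compound 3 to compound 4 (beyond the scatter) is therefore expected, with a wide range. Compound 4 is estimated at 52% in this assay, between 30% and 70%.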

Compound 4, a percentage reported as activity, at one concentration (the size of the read-out at that concentration, not a potency): 66.5%
Estimate against measurement, compound 4: 14.5 percentage points below; measured number inside the range.
By their numbers in this assay, from the lowest: compound 1; then compounds 2, 3 and 4 (each within the scatter of the next).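

The step of a number 2.1 percentage points higher from compound 3 to compound 4 (within the scatter) and the step of a number 4.7 percentage points higher from compound 2 to compound 4 (within the scatter) both stay small, so in this assay chloro, methyl and methoxy on this aromatic carbon do not separate within the pyrimidin-2-yl compounds. The large movement lies at the other place: a step of a number 35 percentage points higher from compound 1 to compound 4 (beyond the scatter) accompanies pyrimidin-2-yl in place of 5-methyl-1,3,4-thiadiazol-2-yl on the sulfur, which ties the low number of compound 1 to that sulfur substituent and not to its methoxy. Nothing shown here accounts for this difference.

Open, from the compounds shown here alone, is whether an amine or a carboxylic acid on this aromatic carbon would move the number beyond the scatter. Also open is whether chloro and methyl match methoxy with 5-methyl-1,3,4-thiadiazol-2-yl on the sulfur, where compound 1 is the only compound shown, and what a simple alkyl chain on the sulfur would give.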